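The source may hold more compounds than are shown below. What is called first, only, known or untested is meant among the compounds shown, and "the series" means these compounds.

Measured so far:
compound 1 `Cc1c(Cn2ccnc2)sc2ccc(C(=O)O)cc12` — > 100000 nM
compound 2 `Cc1c(Cn2ccnc2)sc2cc(C(=O)O)ccc12` — > 100000 nM

In an assay on aorta (Sus scrofa) for inhibition of prostacyclin synthase (Homo sapiens) (on this read-out lower numbers stand for stronger inhibition and higher numbers for weaker inhibition), compound 1 gives > 100000 nM, which is a limit of the assay and not a number. Compound 2 gives > 100000 nM in this assay, likewise a limit. Both measured values stand at the limit of > 100000 nM in this assay, at which 2 of the 2 values shown sit, so compound 1 stands where the assay stops reporting, and no order between compound 1 and compound 2 can be read from these two values.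

Compound 3 `O=C(O)c1ccc2sc(Cn3ccnc3)cc2c1` is not yet measured in this assay. It differs from compound 1 by hydrogen in place of methyl on an aromatic carbon. Going by the values given here, no step between measured compounds exists to gauge a change of this kind, so no direction is expected beyond the scatter.

Compound 3 is expected to sit at the same limit because compound 1 gives > 100000 nM. The estimate for compound 3 is 100000 nM, with a range from 20000 nM to 500000 nM. The expected step is a number no higher from compound 1 to compound 3 (the limit leaves the size open), which is none beyond the scatter.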

Compound 3, half-maximal inhibitory concentration: > 100000 nM
Compound 3 gave a limit, no number; the forecaster's own chance of this, stated with the estimate: 85%; the middle value sits exactly at the limit.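

No step can be read between compound 1 and compound 3, because both stop at a limit of this assay, not a number: the limit of > 100000 nM in this assay, at which 3 of the 3 values shown sit.

The compounds shown leave open how methyl and hydrogen on that aromatic carbon compare, and which change to the shared core would give a readable value.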